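The source may report more compounds than this note shows. Statements on the series, on what has been measured and on what is new or still open speak of the compounds shown alone.

Measured so far:
compound 1 `COc1ccc(/C=C/C(=O)c2ccc(OC)c3c2OC(C)(C)C=C3)c(F)c1` — > 10000 nM
compound 2 `COc1ccc(C(=O)/C=C/c2ccc(N(c3ccccc3)c3ccccc3)cc2)c2c1C=CC(C)(C)O2` — > 10000 nM

Compound 1 `COc1ccc(/C=C/C(=O)c2ccc(OC)c3c2OC(C)(C)C=C3)c(F)c1` has been run in a functional assay on K562 cells (Homo sapiens) for antiproliferative activity, read by MTT assay, with a stated time of 24 h; on this read-out higher numbers stand for weaker inhibition and lower numbers for stronger inhibition; for compound 1 the value > 10000 nM is a limit of the assay, not a number. Compound 2 `COc1ccc(C(=O)/C=C/c2ccc(N(c3ccccc3)c3ccccc3)cc2)c2c1C=CC(C)(C)O2` likewise returns only a limit, > 10000 nM. Every value shown sits at the same point: the limit of > 10000 nM in this assay, at which 2 of the 2 values shown sit. Compound 1 therefore cannot be placed against compound 2 on these numbers; it is simply unresolved at the ceiling of the assay.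

Compound 3 `COc1ccc(C(=O)/C=C/c2ccccc2Cl)c2c1C=CC(C)(C)O2` is still to be measured. It differs from compound 1 in one place: 2-chlorophenyl in place of 2-fluoro-4-methoxyphenyl on a double-bonded chain carbon bound to a double-bonded chain carbon. Within the data shown here, no step between measured compounds is available, so nothing shows how far such a change can move the read-out. In this assay the expected step is a step that the limit leaves unreadable from compound 1 to compound 3, which is not expected to exceed the scatter, with a real chance of another limit. Compound 3 is estimated at 15000 nM, in the range 3000 nM to 60000 nM.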

Compound 3, half-maximal inhibitory concentration: > 10000 nM
Compound 3 was reported as a limit (the forecaster's own chance of this, stated with the estimate: 60%); the middle value lies beyond the limit too.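

No step can be read between compound 1 and compound 3, as both return only limits of the assay, not numbers: the limit of > 10000 nM in this assay, at which 3 of the 3 values shown sit.

The compounds shown leave open whether 2-chlorophenyl in place of 2-fluoro-4-methoxyphenyl moves the read-out at all, and which change to the shared core would give a readable value.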